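This account rests on a few compounds, and the source may have more. Where it says the series, first, only, none or still open, it means among the compounds named here.

Measured compounds:
Compound 1 `CN(Cc1cccs1)C1CCN(CCCc2c[nH]c3ccc(-n4cnnc4)cc23)CC1`: 81%
Compound 2 `c1cc(CNC2CCN(CCCc3c[nH]c4ccc(-n5cnnc5)cc34)CC2)co1`: 65%

In a functional assay on CHO cells for activation of 5-hydroxytryptamine receptor 1D (Homo sapiens), read by GTPgammaS binding (a higher number here means a larger maximal response, a lower number a smaller maximal response), compound 1 gives 81% and compound 2 gives 65%. Among the measured compounds shown here, the only measured step is a number 16 percentage points lower from compound 1 to compound 2 (beyond the scatter), and it leaves compound 2 as the lowest of the two numbers, with compound 1 its sole neighbour.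

Compound 3 `CC(C)=CCN(C)C1CCN(CCCc2c[nH]c3ccc(-n4cnnc4)cc23)CC1` differs from compound 2 by methyl(3-methylbut-2-en-1-yl)amino in place of ((furan-3-yl)methyl)amino on a saturated ring carbon. For the measured compounds named here, only one measured step bears on this change, and only in part: the methyl on the amine nitrogen that compound 1 carries and compound 2 lacks comes back in compound 3, while the ring group gives way to a chain. Taking a number 16 percentage points lower from compound 1 to compound 2 (beyond the scatter) as the sole guide, a modest upward step in this assay is expected, of a size comparable to that step and reaching roughly the level of compound 1. Compound 3 is therefore estimated at 78%, with a range from 62% to 92%. The expected step is a number 13 percentage points higher from compound 2 to compound 3 (beyond the scatter).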

Compound 3, largest response reached (reported as efficacy), in percent of the reference or control that the assay uses: 115%
Beside the measured number, compound 3's estimate is 37 percentage points below it, and the stated range ends below it.
By their numbers in this assay, from the lowest: compound 2; then compound 1; then compound 3.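

In this assay, the ring is not needed for a high maximal response at this position: with the methyl on the amine nitrogen present in both compounds, the open 2-methylprop-1-en-1-yl end gives a number 34 percentage points higher from compound 1 to compound 3 (beyond the scatter), a change on the saturated chain carbon bound to that nitrogen. Against the ((furan-3-yl)methyl)amino group of equal heavy-atom count, the methyl(3-methylbut-2-en-1-yl)amino group gives a number 50 percentage points higher from compound 2 to compound 3 (beyond the scatter), which makes compound 3 the highest of the three, although that step changes both the amine methyl and the end group. Nothing available explains the size of either step.

Going by these compounds, it remains open how much the double bond contributes, which a saturated 3-methylbutyl chain would test. The separate share of the amine methyl also stays unresolved, since the 3-methylbut-2-en-1-ylamino counterpart with a hydrogen on that nitrogen is not among these compounds.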